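The source may hold more compounds than are shown below. What is called first, only, known or untested is meant among the compounds shown, and "the series" means these compounds.

In a functional assay on the whole organism (strain Sprague-Dawley) for inhibition, with Rattus norvegicus as the target (a lower number here means that less compound is needed, a higher number that more compound is needed for the effect), compound 1 `COc1ccc2cc(-c3nn[nH]n3)cnc2c1` gives 5 mg/kg. Compound 2 `O=C(O)c1cnc2cc(C(F)(F)F)ccc2c1` carries a carboxy group on its shared core, and in this assay compound 2 gives > 25 mg/kg, which is a limit of the assay and not a measured number. Going by the values given here, compound 2 therefore stands at the limit of > 25 mg/kg in this assay, at which 1 of the 2 values shown sits, so its true value is known only in one direction, and no step between the two measured compounds can be computed from these data.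

Compound 3 `FC(F)(F)c1ccc2cc(-c3nn[nH]n3)cnc2c1` differs from compound 2 in one place: 2H-tetrazol-5-yl in place of carboxy on an aromatic carbon. The 2H-tetrazol-5-yl group is also the group that compound 1 carries on its core, and compound 1 gives a measured number, 5 mg/kg, rather than a limit.

For compound 3, the step from the limit of compound 2 is expected to go toward a lower number and to lie beyond the scatter, with an at least 3.1-fold lower number from compound 2 to compound 3 (0.49 log units; beyond the scatter) as the expected size. Compound 3 is therefore expected to give about 8 mg/kg in this assay, somewhere between 2 mg/kg and 25 mg/kg.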

Compound 3, minimum effective dose: < 10 mg/kg
Compound 3 was reported as a limit; the forecaster's own chance of this, stated with the estimate: 30%; the middle value does not contradict the limit.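

With the trifluoromethyl group kept on the shared core, placing 2H-tetrazol-5-yl instead of carboxy on this aromatic carbon, two atoms from the ring nitrogen, gives an at least 2.5-fold lower number from compound 2 to compound 3 (0.39 log units; beyond the scatter) in this assay, so less compound is needed for the effect and this is the only readable step among the compounds shown. The result for compound 3 is a limit of the assay and not a measured number, so its true value is known in one direction only: the limit of < 10 mg/kg in this assay, at which 1 of the 3 values shown sits. The result for compound 2 is likewise a limit and not a measured number, so the step gives a smallest size for the gain and no exact size: the limit of > 25 mg/kg in this assay, at which 1 of the 3 values shown sits.

As far as these compounds go, the step from compound 1 to compound 3, trifluoromethyl in place of methoxy, cannot be read, so what that exchange does with the 2H-tetrazol-5-yl group in place remains unknown. Also open, from the compounds shown here alone, is how another group on the same aromatic carbon, such as a nitrile or a primary amide, would compare with 2H-tetrazol-5-yl and carboxy.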